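Mirror-image pair in monkey plasma exposure

This account rests on a few compounds, and the source may have more. Where it says the series, first, only, none or still open, it means among the compounds named here.

Measured compounds:
compound 1, `CC(C)(C)CCN1C(=O)C(C2=NS(=O)(=O)c3cc(NS(C)(=O)=O)ccc3N2)=C(O)C2CCCCC21`, 3520 ng.h/mL
compound 2, `CS(=O)(=O)Nc1ccc2c(c1)S(=O)(=O)N=C(C1=C(O)[C@H]3CCCC[C@H]3N(Cc3ccc(F)cc3)C1=O)N2`, 25300 ng.h/mL

In an ADME assay on the whole organism (plasma) for pharmacokinetics, with Cynomolgus monkey (Macaca fascicularis) as the target, at a dose of 1 mg/kg by the intravenous route (a higher number here means more compound in the circulation at the dose given, a lower number less compound in the circulation), compound 1 gives 3520 ng.h/mL. Going by the values given here, in the same assay compound 2 gives 25300 ng.h/mL, the higher of the two numbers; the gap to compound 1 is beyond the scatter, but the two compounds differ in more than one place and no single step between them is described, so only their two values can be compared.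

Compound 3, `CS(=O)(=O)Nc1ccc2c(c1)S(=O)(=O)N=C(C1=C(O)[C@@H]3CCCC[C@@H]3N(Cc3ccc(F)cc3)C1=O)N2`, has yet to be measured in this assay. Its relation to compound 2 is as follows: the two compounds have the same atoms and bonds and differ only in configuration as drawn: 2 of 2 stereo elements differ (all stereocentres are inverted: mirror images); a stereocentre at a saturated ring carbon is drawn S in compound 2 and R in compound 3; a stereocentre at a saturated ring carbon is drawn R in compound 2 and S in compound 3. Among the compounds with values here, nothing among the measured compounds shows how the mirror image of a compound of this series behaves in this assay, and compound 1 carries no drawn configuration at its ring carbons, so it offers no guide. Compound 3 is therefore expected to show no step beyond the scatter, a 1.4-fold lower number from compound 2 to compound 3 (0.15 log units; within the scatter), with a wide range allowed in either direction. The estimate for compound 3 in this assay is 18000 ng.h/mL, between 6000 ng.h/mL and 45000 ng.h/mL.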

Compound 3, area under the concentration-time curve: 10000 ng.h/mL
Compound 3: middle estimate off by 1.8-fold (0.26 log units), on the high side, and the stated range covers the measured number.
By their numbers in this assay, from the lowest: compound 1; then compound 3; then compound 2.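

Inverting both ring carbons changes the reading in this assay, giving a 2.5-fold lower number from compound 2 to compound 3 (0.40 log units; beyond the scatter), a modest step but one that lies beyond the scatter, so the drawn configuration at these two carbons matters for exposure in the monkey. The earlier comparison could not show this: compound 1 and compound 2 differ in more than one place, and compound 1 carries no drawn configuration at its ring carbons. This pair isolates a single change, and the step can be assigned to configuration alone because no atom or bond separates the two compounds: the fact that compounds 2 and 3 differ only in the configuration as drawn

What the compounds shown leave open is why the mirror images differ, since a single exposure figure for each does not tell how the compound is cleared or distributed, and one pair does not show whether the other two possible arrangements at these carbons would read higher or lower. Nor do they tell whether a step of this size would persist if the fluorobenzyl group gave way to a longer chain, an amine or a carboxylic acid.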